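The source may hold more compounds than are shown below. What is called first, only, known or untested is meant among the compounds shown, and "the series" means these compounds.

Measured compounds in a functional assay on DU-145 cells (Homo sapiens) for cytotoxicity, read by CCK-8 assay and cell counting, with a stated time of 2 days; a higher number here means a weaker inhibitor, a lower number a stronger inhibitor:
- compound 1, `Oc1ccc(-c2cc(-c3ccc(Cl)cc3)nc(-c3cccnc3)c2)cc1`: compound 1 gives 22800 nM
- compound 2, `Oc1cccc(-c2cc(-c3ccc(Cl)cc3)nc(-c3cccnc3)c2)c1`: compound 2 gives 26800 nM
- compound 3, `Oc1ccc(-c2cc(-c3cccnc3)nc(-c3ccccc3Cl)c2)cc1`: compound 3 gives "not determined" (no result reported)

Going by the values given here, compound 1 holds the lower of the two numbers available in this assay, but its only neighbour is compound 2, and the step of a 1.2-fold higher number from compound 1 to compound 2 (0.07 log units; within the scatter), which exchanges a 4-hydroxyphenyl for a 3-hydroxyphenyl on an aromatic carbon, lies within the scatter, so the two compounds are not separated by this measurement. Compound 3 carries no number and adds nothing to the comparison.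

The next compound, compound 4, `Oc1ccc(-c2cc(-c3ccc(Cl)cc3)nc(-c3ccco3)c2)cc1`, differs from compound 1 in one place: furan-2-yl in place of pyridin-3-yl on an aromatic carbon. Among the compounds with values here, no measured step touches this position or this pair of groups; the one step that is known, from compound 1 to compound 2, concerns the hydroxyphenyl group instead and was itself within the scatter. There is therefore no basis in the present numbers for expecting a shift in either direction in this assay beyond the scatter.

On that footing, compound 4 is expected to give about 23000 nM in this assay, with a range of 8000 nM to 65000 nM, which means an expected step of a 1.0-fold higher number from compound 1 to compound 4 (0.00 log units; within the scatter) from compound 1, essentially flat.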

Compound 4, half-maximal inhibitory concentration: 7280 nM
Compound 4: middle estimate off by 3.2-fold (0.50 log units), on the high side, and the stated range ends above it.
By their numbers in this assay, from the lowest: compound 4; then compounds 1 and 2 (each within the scatter of the next).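

Going by these compounds alone, the position next to the ring nitrogen responds in this assay: furan-2-yl in place of pyridin-3-yl gives a 3.1-fold lower number from compound 1 to compound 4 (0.50 log units; beyond the scatter), the only step so far beyond the scatter, whereas moving the hydroxyl group gave a 1.2-fold higher number from compound 1 to compound 2 (0.07 log units; within the scatter) and left compounds 1 and 2 unseparated. The exchange replaces a six-membered aromatic ring holding a nitrogen with a five-membered aromatic ring holding an oxygen, while the hydrogen-bond donor and acceptor counts stay the same, so this single step cannot say whether ring size or the identity of the hetero atom matters. Nothing measured here accounts for the shift at this position.

On these data alone, with a single replacement at this position, it remains open whether thiophen-2-yl, a plain phenyl ring or a group of another kind, such as an amine, would follow furan-2-yl or pyridin-3-yl. As far as these compounds go, it also remains open whether the step seen with the 4-hydroxyphenyl group would carry over to a compound bearing furan-2-yl together with the 3-hydroxyphenyl group of compound 2.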